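A pyranone cap in place of the oxamide

A few compounds are considered here, and "the series" means these few. Any claim that something is new, unique, unknown or untested is made for them only; others in the source may bear on it.

Compound 2 `NC(=O)C(=O)NCCCCCC(=O)Nc1ccccc1` gives only a limit in a functional assay on HCT-116 cells (Homo sapiens) for inhibition, read by colorimetric assay, with a stated time of 3 days (on this read-out higher numbers stand for weaker inhibition and lower numbers for stronger inhibition), namely > 100000 nM. The two compounds with a number, compound 1 `O=C(CCCCCCNC(=O)C(O)(O)C(F)(F)F)Nc1nc2ccc(Br)cc2o1` at 12100 nM and compound 3 `O=C(CCCCCCNC(=O)C(O)(O)C(F)(F)F)Nc1cccc2ccccc12` at 6480 nM, both carry a hydrated trifluoromethyl carbonyl end group, and both sit well inside the measured range. Compound 4 `O=C(CCCCCNC(=O)c1cc(=O)c(O)co1)Nc1ccccc1` differs from compound 2 in one place: a group of 8 heavy atoms (5 carbon, 3 oxygen; one six-membered aromatic ring with 1 hetero atom) in place of a group of 3 heavy atoms (1 carbon, 1 nitrogen, 1 oxygen; no ring), on a carbonyl carbon. Going by the values given here, no measured pair shows a step of this kind, so its size can only be guessed against the limit of compound 2 (the limit of > 100000 nM in this assay, at which 1 of the 3 values shown sits). Compound 4 is expected to come inside the range, with an estimated 40000 nM (from 8000 nM to 200000 nM). That would mean an expected step of an at least 2.5-fold lower number from compound 2 to compound 4 (0.39 log units; beyond the scatter) toward stronger inhibition.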

Compound 4, half-maximal inhibitory concentration: > 100000 nM
Compound 4 was reported as a limit; the forecaster's own chance of this, stated with the estimate: 35%; at least 2.5-fold (0.39 log units) between middle value and limit.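

Compound 2 and compound 4 are both reported only as limits, so no step between them can be read: the limit of > 100000 nM in this assay, at which 2 of the 4 values shown sit.

The compounds shown leave open whether this change of group alters inhibition at all, as no pair differing in one place has two measured numbers.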